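This account rests on a few compounds, and the source may have more. Where it says the series, first, only, none or still open, it means among the compounds named here.

Values so far in a functional assay on HeLa cells (Homo sapiens) for inhibition, read by CCK-8 assay, with a stated time of 72 h, tested at 8 uM (a lower number here means less inhibition of growth, a higher number more inhibition of growth at the concentration tested), for the measured compounds

- compound 1 `COc1ccc(SCc2ccc(/C=C/C(=O)Nc3ccccc3N)cc2)cc1OC` gives 21.9%
- compound 2 `Nc1ccccc1NC(=O)/C=C/c1ccc(CSc2ccc(Cl)cc2)cc1` gives 17.3%
- compound 3 `COc1ccc(SCc2ccc(C(=O)Nc3ccccc3N)cc2)cc1` gives 79.7%

Compound 3 holds the highest of these three values, and its gaps to both other compounds lie beyond the usual scatter. Compound 1 and compound 2 lie within the scatter of each other.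

Compound 4 `Nc1ccccc1NC(=O)c1ccc(CSc2cccc(F)c2)cc1` has not yet been measured. It departs from compound 3 by a single exchange 3-fluorophenyl in place of 4-methoxyphenyl on a sulfur in which 3-fluorophenyl stands in place of 4-methoxyphenyl on a sulfur whose other neighbour is a saturated chain carbon.

Among the measured compounds shown here, only one measured step involves an exchange at this place: a number 4.6 percentage points lower from compound 1 to compound 2 (within the scatter) with 4-chlorophenyl in place of 3,4-dimethoxyphenyl on a sulfur. That step stayed within the scatter, which gives no sign that this place moves the read-out much. It is only a loose guide, however, since it comes from a core unlike that of compound 3 and from much lower values. For the measured compounds named here, no measured pair tests an exchange at this place on the core of compound 3, so the range is kept wide.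

No step beyond the scatter is therefore expected in this assay and the estimated change is a number 4.7 percentage points lower from compound 3 to compound 4 (within the scatter) with no firm direction implied. For compound 4 the estimated value is 75% with an expected range from 52% to 92% in this read-out.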

Compound 4, percent growth inhibition at one concentration: 78.4%
For compound 4 the middle estimate is 3.4 percentage points below the measured one; low and high end bracket the measured number.
By their numbers in this assay, from the lowest: compounds 2 and 1 (each within the scatter of the next); then compounds 4 and 3 (each within the scatter of the next).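

In this assay the exchange on the sulfur reads as a number 1.3 percentage points lower from compound 3 to compound 4 (within the scatter) and so supplies a measured step at this place on the core of compound 3, where growth inhibition is high. Among the compounds shown here, the only other step at this place (a number 4.6 percentage points lower from compound 1 to compound 2 (within the scatter)) comes from a different core with low values, so two exchanges of the aryl group on the sulfur, on two different cores and at very different levels of the read-out, now both stay within the scatter. Nothing measured on the compounds offers an explanation for this result.

The single exchange replaces 4-methoxyphenyl with 3-fluorophenyl as a whole, so the compounds shown leave open what the methoxy group, the fluorine and their places on the ring each contribute, and a single tested concentration cannot separate compound 3 from compound 4 in potency. Also open, on these data alone, is whether the aryl group on the sulfur can give way to a group of another kind, such as a phenyl ring carrying an amine or a carboxylic acid, or a longer chain on the sulfur, with the read-out staying at this level.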